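A few compounds are considered here, and "the series" means these few. Any claim that something is new, unique, unknown or untested is made for them only; others in the source may bear on it.

Measured so far:
compound 1 `CO[C@@H]1C[C@@H](C(=O)NCCN(C)C)N(C(=O)NCc2ccc(C(=O)N3CCCCc4sccc43)cc2Cl)C1`; in an assay on isolated protein with Oxytocin receptor (Homo sapiens) as the target (a lower number here means that less compound is needed, a higher number that more compound is needed for the effect), compound 1 reaches only the assay limit of > 10000 nM.
compound 2 `CO[C@@H]1C[C@@H](C(=O)N2CCC(N3CCCCC3)CC2)N(C(=O)NCc2ccc(C(=O)N3CCCCc4sccc43)cc2Cl)C1`; in this assay compound 2 gives 2200 nM.

Among the compounds with values here, compound 2 carries the only number in this assay; the other value is a limit (the limit of > 10000 nM in this assay, at which 1 of the 2 values shown sits). Compound 3 `CO[C@@H]1C[C@@H](C(=O)N2CCC(N3CCCC3)CC2)N(C(=O)NCc2ccc(C(=O)N3CCCCc4sccc43)cc2Cl)C1` differs from compound 2 by pyrrolidin-1-yl in place of piperidin-1-yl on a saturated ring carbon. Within the data shown here, the single measured step, an at least 4.5-fold lower number from compound 1 to compound 2 (0.65 log units; beyond the scatter), exchanges the whole group on that carbonyl and does not touch the ring varied here, so it bears only loosely. The expected step from compound 2 to compound 3 is therefore within the scatter: a 1.1-fold lower number from compound 2 to compound 3 (0.04 log units; within the scatter). For compound 3 the estimate in this assay is 2000 nM, between 700 nM and 6000 nM.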

Compound 3, half-maximal effective concentration: 2300 nM
The estimate for compound 3 lay 1.2-fold (0.06 log units) below the measured number; low and high end bracket the measured number.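

In this assay, the saturated ring carbon three ring bonds from the ring nitrogen takes pyrrolidin-1-yl in place of piperidin-1-yl with no change beyond the scatter: a 1.0-fold higher number from compound 2 to compound 3 (0.02 log units; within the scatter). The lower number relative to the (2-(dimethylamino)ethyl)amino group therefore holds for both ring sizes, with an at least 4.3-fold lower number from compound 1 to compound 3 (0.63 log units; beyond the scatter). Compound 1 stands at an assay limit: the limit of > 10000 nM in this assay, at which 1 of the 3 values shown sits.

On these data alone, what a morpholin-4-yl or azepan-1-yl group would give on this carbon remains open. So does whether a dimethylamino group there, without a second ring, would retain the lower number.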